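Swapping Fluoro for Methoxy on the Aromatic Ring

This account rests on a few compounds, and the source may have more. Where it says the series, first, only, none or still open, it means among the compounds named here.

Compound 3 `CC(C)(C)OC(=O)N1CCC(CCOC(=O)N2CCc3cc(S(C)(=O)=O)c(F)cc32)CC1` gives 160 nM in a functional assay on CHO cells for agonist activity at Glucose-dependent insulinotropic receptor (Homo sapiens), read by a luciferase reporter and cAMP accumulation, with a stated time of 2 h (a higher number here means that more compound is needed for the effect, a lower number that less compound is needed), the second highest of three numbers: compound 1 `CC(C)(C)OC(=O)N1CCC(CCOC(=O)N2CCc3cc(S(C)(=O)=O)ccc32)CC1` gives 68 nM, while compound 2 `CC(CC1CCN(C(=O)OC(C)(C)C)CC1)OC(=O)N1CCc2cc(S(C)(=O)=O)ccc21` gives 2600 nM. Compound 4 `COc1cc2c(cc1S(C)(=O)=O)CCN2C(=O)OCCC1CCN(C(=O)OC(C)(C)C)CC1` differs from compound 3 by methoxy in place of fluoro on an aromatic carbon. Among the compounds with values here, no measured step exchanges these two groups directly. The step that bears most closely is a 2.4-fold higher number from compound 1 to compound 3 (0.37 log units; beyond the scatter), which touches the same aromatic carbon. The step of a 38-fold higher number from compound 1 to compound 2 (1.58 log units; beyond the scatter) sits on a chain carbon and says little about a change on the ring. A modest step in either direction, or none beyond the scatter, is therefore expected for this assay. Compound 4 is estimated at 200 nM, within 60 nM to 700 nM, so the expected step is a 1.3-fold higher number from compound 3 to compound 4 (0.10 log units; within the scatter).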

Compound 4, half-maximal effective concentration in the Glucose-dependent insulinotropic receptor assay: 4800 nM
Estimate against measurement, compound 4: 24-fold (1.38 log units) below; the whole stated range lies below it.
By their numbers in the Glucose-dependent insulinotropic receptor assay, from the lowest: compound 1; then compound 3; then compounds 2 and 4 (each within the scatter of the next).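

On this aromatic carbon, the identity of the group matters far more than the modest fluoro step suggested: in the Glucose-dependent insulinotropic receptor assay, methoxy gives a 30-fold higher number from compound 3 to compound 4 (1.48 log units; beyond the scatter), and measured against hydrogen it gives a 71-fold higher number from compound 1 to compound 4 (1.85 log units; beyond the scatter). A small step for one group at this position therefore does not predict the step for another. In a physicochemical assay for solubility, read by HPLC, at pH 6.8 (on this read-out higher numbers stand for higher solubility and lower numbers for lower solubility), compound 3 gives 0.67 ug/mL and compound 4 gives 45 ug/mL. In the physicochemical assay, the same exchange moves the other way in practical terms, towards higher solubility: the measured solubility of compound 3, 0.67 ug/mL, and of compound 4, 45 ug/mL, a 67-fold higher number (1.83 log units; beyond the scatter)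

The compounds shown leave open whether a chloro or a hydroxy group on this carbon could keep a number close to that of compound 1 while retaining the solubility of compound 4.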